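Compound 2 to compound 3: a new aromatic group

The compounds below may be only part of what the source reports. "The series", "measured", "known", "first", "only" and "open" are said of these compounds alone.

Compound 1 `Clc1ccc(NCc2cncn2Cc2ccc(-c3ccccc3)cc2)cc1-c1ccccc1`: > 1000 nM
Compound 2 `O=C(c1ccc(NCc2cncn2Cc2ccc(-c3ccccc3)cc2)cc1-c1ccccc1)N1CCCCC1`: > 1000 nM

In a toxicity assay on NIH3T3 cells (Mus musculus) for cytotoxicity, read by resazurin assay (a lower number here means that less compound is needed, a higher number that more compound is needed for the effect), compound 2 gives > 1000 nM, which is a limit and not a number. Compound 1 gives > 1000 nM, also a limit. The evidence so far is therefore (the limit of > 1000 nM in this assay, at which 2 of the 2 values shown sit).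

Compound 3 `c1ccc(-c2ccc(Cn3cncc3CNc3ccc(-c4nc5ccccc5s4)c(-c4ccccc4)c3)cc2)cc1` changes one group of compound 2: 1,3-benzothiazol-2-yl in place of (piperidin-1-yl)carbonyl on an aromatic carbon. Among the compounds with values here, the only measured step, a step that the two limits leave unreadable from compound 1 to compound 2, has no readable size, so it offers no size or direction to carry over. In this assay the expected change is therefore none that can be stated with confidence, and the estimated step is a step that the limit leaves unreadable from compound 2 to compound 3. Compound 3 is expected at 3000 nM, with an estimated range of 600 nM to 15000 nM.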

Compound 3, half-maximal effective concentration: > 1000 nM
Compound 3: only a limit was reported (the forecaster's own chance of this, stated with the estimate: 65%); the middle value does not contradict the limit.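

Within the data shown here, the values of compound 1, compound 2 and compound 3 are all limits and not numbers, so no step between them can be read. The compounds shown leave open the concentration at which any of them reaches the half-maximal effect in this assay.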